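Amide to urea on the aryl tail of the pyrazole series

The source may hold more compounds than are shown below. What is called first, only, known or untested is meant among the compounds shown, and "the series" means these compounds.

Of the compounds shown here, two have a number so far. In a functional assay on MDA-MB-468 cells (Homo sapiens) for inhibition, read by sulforhodamine B assay, with a stated time of 48 h (a lower number here means a stronger inhibitor of growth, a higher number a weaker inhibitor of growth), compound 1 `COc1cc(-c2nn(-c3cccc(NC(=O)c4cccc(C(F)(F)F)c4)c3)cc2-c2ccncc2)ccc1Cl` gives 4560 nM, the highest of the two numbers. Compound 2 `O=C(Nc1cccc(-n2cc(-c3ccncc3)c(-c3ccc(Cl)c(O)c3)n2)c1)Nc1cc(C(F)(F)F)cc(C(F)(F)F)c1` differs from compound 1 in several places. In this assay compound 2 gives 2660 nM; the gap between the two sits within the scatter, so no order between them can be read.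

Compound 3 `COc1cc(-c2nn(-c3cccc(NC(=O)Nc4ccc(Cl)c(C(F)(F)F)c4)c3)cc2-c2ccncc2)ccc1Cl` has not yet been measured. It is reached from compound 1 by a single change: (4-chloro-3-(trifluoromethyl)phenyl)amino in place of 3-(trifluoromethyl)phenyl on a carbonyl carbon. Among the compounds with values here, no step between measured compounds that differ in only one place is available, so the size of this step has to be judged from the two values alone. The value of compound 2 in this assay stands within the scatter of compound 1, which gives no ground for expecting a large move in either direction.

For compound 3 the estimated step from compound 1 is a 1.5-fold lower number from compound 1 to compound 3 (0.18 log units; within the scatter), expected to stay within the scatter. Compound 3 is estimated at 3000 nM in this assay, with a range from 1000 nM to 8000 nM.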

Compound 3, concentration for total growth inhibition: 4420 nM
For compound 3 the middle estimate is 1.5-fold (0.17 log units) below the measured one; measured number inside the range.
By their numbers in this assay, from the lowest: compounds 2, 3 and 1 (each within the scatter of the next).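

In this assay the series now has its first step between compounds that differ in one place: (4-chloro-3-(trifluoromethyl)phenyl)amino in place of 3-(trifluoromethyl)phenyl on a carbonyl carbon gives a 1.0-fold lower number from compound 1 to compound 3 (0.01 log units; within the scatter). This position therefore accepts the turn from amide to urea, with a chlorine added to the aryl ring, without a readable move in growth inhibition. The amino nitrogen and the chlorine enter together, so this single step cannot show what each contributes alone, and nothing measured here offers an explanation for the flat result.

Steps to compound 2 cannot be read, as it differs from the other compounds in several places, so the wider effect of its tail and its other differences remains unresolved. Still open, going by these compounds, is whether the 4-chloro-3-(trifluoromethyl)phenyl group joined directly to the carbonyl carbon, without the amino nitrogen, would match compound 3, and whether a piperazine or a cyclohexyl group on that carbon would leave the number within the scatter.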